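Swapping benzylcarbamoyl for acetamido on a shared core

The compounds below may be only part of what the source reports. "The series", "measured", "known", "first", "only" and "open" are said of these compounds alone.

Measured in a physicochemical assay for lipophilicity, at pH 7.4; a lower number here means a more polar compound, a higher number a more lipophilic compound:
Compound 1 `Cc1cc(C(N)=O)nn1Cc1cc(Cl)ccc1OCc1ccccc1` gives 3.7
Compound 2 `Cc1cc(C(=O)Nc2ccc(F)cc2)nn1Cc1cc(Cl)ccc1OCc1ccccc1` gives 3
Compound 3 `Cc1cc(C(=O)NCc2ccccc2)nn1Cc1cc(Cl)ccc1OCc1ccccc1` gives > 3.7 (a limit, not a number)

Compound 3 gives > 3.7 in this assay, and this is a limit of the assay and not a number.

Compound 4 `CC(=O)Nc1cc(C)n(Cc2cc(Cl)ccc2OCc2ccccc2)n1` has not yet been measured. It differs from compound 3 in one place: acetamido in place of benzylcarbamoyl on an aromatic carbon. Acetamido stands in place of benzylcarbamoyl on an aromatic carbon.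

Among the measured compounds shown here, no measured step makes this exact change, but three steps concern the group on an amide-type nitrogen. Replacing hydrogen with 4-fluorophenyl gives a number 0.70 log units lower from compound 1 to compound 2 (beyond the scatter), a modest step beyond the scatter. Replacing hydrogen with benzyl gives a number no lower from compound 1 to compound 3 (the limit leaves the size open), and the limit leaves its size open. Replacing 4-fluorophenyl with benzyl gives a number at least 0.70 log units higher from compound 2 to compound 3 (beyond the scatter), again beyond the scatter.

Compound 4 carries no benzyl. The measured compounds without benzyl are compound 1, with 3.7, and compound 2, with 3. A modest move towards a lower number is therefore expected, and the estimated step is a number at least 0.40 log units lower from compound 3 to compound 4 (beyond the scatter) in this assay. For compound 4 the expected value is 3.3, with an estimated range from 2.8 to 3.8.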

Compound 4, distribution coefficient: > 3.7
Compound 4 was reported as a limit; the forecaster's own chance of this, stated with the estimate: 10%; middle value at least 0.40 log units away from the limit.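

In this assay, acetamido in place of (4-fluorophenyl)carbamoyl on an aromatic carbon gives a number at least 0.70 log units higher from compound 2 to compound 4 (beyond the scatter). Taking the aromatic ring out of the group at this position, as happens between compound 3 and compound 4, therefore does not on its own bring a compound down towards compound 2, and the smaller acetamido group stays at the high end of this small set. The result for compound 4 is a limit of the assay and not a number, the same limit as for compound 3. Acetamido in place of carbamoyl on an aromatic carbon gives a number no lower from compound 1 to compound 4 (the limit leaves the size open) and the size of that step cannot be read, nor can the step from compound 3 to compound 4: the limit of > 3.7 in this assay, at which 2 of the 4 values shown sit.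

From the compounds shown here alone, how far compound 4 lies past that limit, and so whether acetamido or benzylcarbamoyl gives the higher number, stays open. The compounds shown also leave open how an amine, a carboxylic acid or a longer chain on this aromatic carbon would read in this assay, and whether any of these would give a number clear of the limit.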